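Adding an Aminopyrazole to a Potent Kinase Binder

A few compounds are considered here, and "the series" means these few. Any claim that something is new, unique, unknown or untested is made for them only; others in the source may bear on it.

Compound 2 `C[C@@H]1CCCN1c1c(C#N)c2c(N)ncnc2n1C` gives the lowest number of the three in an assay on isolated protein for binding affinity to Leucine-rich repeat serine/threonine-protein kinase 2 variant G2019S (Homo sapiens), read by TR-FRET and LanthaScreen, with a stated time of 2 h (on this read-out higher numbers stand for weaker inhibition and lower numbers for stronger inhibition), at 0.7 nM. Compound 1 `CN(C)c1c(C#N)c2c(N)ncnc2n1C` gives 259 nM, and compound 3 `C[C@@H]1CCCN1c1c(C(N)=O)c2c(N)ncnc2n1C` gives 154 nM. Both measured steps are large: a 370-fold lower number from compound 1 to compound 2 (2.57 log units; beyond the scatter) and a 220-fold higher number from compound 2 to compound 3 (2.34 log units; beyond the scatter). Compound 4 `Cc1n[nH]cc1Nc1nc(N)c2c(C#N)c(N3CCC[C@H]3C)n(C)c2n1` differs from compound 2 in one place: (3-methyl-1H-pyrazol-4-yl)amino in place of hydrogen on an aromatic carbon. Neither measured step touches this position, so they do not bear directly on the new change; they only show that single changes elsewhere on the shared core moved the numbers a great deal. Compound 2 already gives 0.7 nM, leaving little room for a lower number. Among the compounds with values here, with no direct precedent, the expected step is small and of uncertain direction: a 1.4-fold higher number from compound 2 to compound 4 (0.15 log units; within the scatter). For compound 4 the estimate is 1 nM, with a range from 0.2 nM to 5 nM.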

Compound 4, inhibition constant: 2 nM
Compound 4: the middle estimate sits 2.0-fold (0.30 log units) below what was measured; low and high end bracket the measured number.
By their numbers in this assay, from the lowest: compound 2; then compound 4; then compounds 3 and 1 (each within the scatter of the next).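

This position on the shared core, an aromatic carbon between two ring nitrogen atoms, accepts a sizeable addition: in this assay, (3-methyl-1H-pyrazol-4-yl)amino in place of hydrogen gives a 2.9-fold higher number from compound 2 to compound 4 (0.46 log units; beyond the scatter) and so a modest step, unlike the large steps seen at the two other changed positions. No evidence here explains the rise in the number.

Going by these compounds, whether a plain amine or a pyrazole without its methyl group would fare the same at this position stays open. So does whether the addition would behave alike on the carbamoyl of compound 3.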